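The source may report more compounds than this note shows. Statements on the series, on what has been measured and on what is new or still open speak of the compounds shown alone.

Compound 1 `O=C(OCc1ccccc1)N1CCN(C(=S)SCc2cn(Cc3ccc(Cl)cc3)nn2)CC1` and compound 2 `O=C(OCc1ccccc1)N1CCN(C(=S)SCc2cn(Cc3ccc(F)cc3)nn2)CC1` share one core. In a functional assay on MGC-803 cells (Homo sapiens) for inhibition, read by MTT assay, with a stated time of 72 h (on this read-out higher numbers stand for weaker inhibition and lower numbers for stronger inhibition), compound 1 gives 31300 nM, and compound 2 gives 17600 nM. For the measured compounds named here, the only measured step, a 1.8-fold lower number from compound 1 to compound 2 (0.25 log units; within the scatter), separates them. On these numbers compound 2 stands at the lowest of the two values, and its nearest neighbour, compound 1, lies within the scatter of it. Compound 3 `COc1cc(Cn2cc(CSC(=S)N3CCN(C(=O)OCc4ccccc4)CC3)nn2)cc(OC)c1OC` carries 3,4,5-trimethoxyphenyl in place of 4-fluorophenyl on a saturated chain carbon bound to an aromatic nitrogen. Going by the values given here, no measured step exchanges the whole aromatic group in this way; the single halogen exchange, itself within the scatter, bears on the change only loosely, and there is no ground in the data to expect a step beyond the scatter in either direction in this assay, though the wider change leaves a wider uncertainty. Compound 3 is therefore estimated at 12000 nM, within 2000 nM to 60000 nM. This estimate corresponds to an expected 1.5-fold lower number from compound 2 to compound 3 (0.17 log units; within the scatter).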

Compound 3, half-maximal inhibitory concentration: 10900 nM
For compound 3 the middle estimate is 1.1-fold (0.04 log units) above the measured one; the measured number falls inside the stated range.
By their numbers in this assay, from the lowest: compounds 3, 2 and 1 (each within the scatter of the next, the first and the last beyond it).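

Exchanging the whole aromatic group on a saturated chain carbon bound to an aromatic nitrogen is a far larger change than the earlier halogen exchange, yet in this assay 3,4,5-trimethoxyphenyl in place of 4-fluorophenyl gives only a 1.6-fold lower number from compound 2 to compound 3 (0.21 log units; within the scatter) and leaves the two compounds indistinguishable. Against 4-chlorophenyl the same group gives a 2.9-fold lower number from compound 1 to compound 3 (0.46 log units; beyond the scatter) and so provides the first modest step beyond the scatter at this position, although compound 2 lies within the scatter of both other compounds. Nothing shown gives a cause for either step.

The compounds shown leave open whether a single methoxy group on the phenyl ring would give a similar number. They also leave open how a non-aromatic group, such as an amine or a carboxylic acid, would behave at this place.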